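Arylamine in Place of Cyclohexylmethylamine on a Shared Core

The compounds below may be only part of what the source reports. "The series", "measured", "known", "first", "only" and "open" are said of these compounds alone.

Compound 1: `Clc1ccccc1Cn1nnc2c(NCC3CCCCC3)ncnc21` — 4260 nM
Compound 2: `Cc1cccc(Nc2ncnc3c2nnn3Cc2ccccc2)c1` — 1100 nM

Among the measured compounds shown here, in an assay on cell membranes for binding affinity to adenosine receptor A1 (Bos taurus), read by radioligand binding (on this read-out higher numbers stand for weaker inhibition and lower numbers for stronger inhibition), compound 1 gives 4260 nM, the highest of the two numbers measured so far. Compound 2 gives 1100 nM, a lower number, and the gap between the two lies beyond the usual scatter. Compound 3 `O=[N+]([O-])c1cccc(Nc2ncnc3c2nnn3Cc2ccccc2Cl)c1` differs from compound 1 in one place: 3-nitrophenyl in place of cyclohexylmethyl on a nitrogen on an aromatic ring. Compound 2, whose ring nitrogen likewise bears an aromatic ring rather than a saturated one, gives the lower number, so a move towards a lower number is expected for compound 3 in this assay. For the measured compounds named here, no measured pair shows how the nitro group itself behaves, and compound 3 also keeps the chlorine that compound 2 lacks, so the range remains wide. The step from compound 1 to compound 3 is expected to be a 2.8-fold lower number from compound 1 to compound 3 (0.45 log units; beyond the scatter). Compound 3 is therefore estimated at 1500 nM, within 400 nM to 6000 nM.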

Compound 3, inhibition constant: 3300 nM
Compound 3: the middle estimate sits 2.2-fold (0.34 log units) below what was measured, and the stated range covers the measured number.
By their numbers in this assay, from the lowest: compound 2; then compounds 3 and 1 (each within the scatter of the next).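

In this assay, putting 3-nitrophenyl in place of cyclohexylmethyl on a nitrogen on an aromatic ring gives a 1.3-fold lower number from compound 1 to compound 3 (0.11 log units; within the scatter) and so stays within the scatter. With the chlorine kept on both compounds, this single change therefore shows that a six-membered aromatic ring and a saturated one on this nitrogen cannot be told apart in this read-out, for this pair. Nothing available offers an explanation for this result.

Compound 2 differs from compound 1 and from compound 3 in more than one place, so what sets its number apart cannot be assigned to any single group. On these data alone, it also remains open whether an amine or a carboxylic acid in place of the nitro group would leave the number within the scatter.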